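Adding a Chlorine to a Benzyl Group

The source may report more compounds than this note shows. Statements on the series, on what has been measured and on what is new or still open speak of the compounds shown alone.

Of the compounds shown here, two of a shared core have been tested in a functional assay on the whole organism (artery, strain albino) with Rattus norvegicus as the target, with a stated time of 600 min, at a dose of 10 mg/kg by the oral route; on this read-out higher numbers stand for more inhibition at the one dose given (going by the name of the read-out) and lower numbers for less inhibition. Compound 1 `COc1ccc(C2N=C(SCc3ccccc3Cl)NC(C)=C2C(=O)Nc2ccc(F)cc2)cc1OC` carries a 2-chlorobenzyl group on its sulfur and a dimethoxyphenyl group; in this assay compound 1 gives 30.3%. Compound 2 `CC1=C(C(=O)Nc2ccc(F)cc2)C(c2ccc([N+](=O)[O-])cc2)N=C(SCc2ccccc2)N1` instead carries a plain benzyl group on the sulfur and a nitrophenyl group; in this assay compound 2 gives 32.3%. The two numbers lie within the usual scatter of each other, so compound 2 cannot be told apart from compound 1 on these readings, and no comparison of a single change is available from them.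

Compound 3 `CC1=C(C(=O)Nc2ccc(F)cc2)C(c2ccc([N+](=O)[O-])cc2)N=C(SCc2ccccc2Cl)N1` keeps everything of compound 2 and differs from it in one place: chloro in place of hydrogen on an aromatic carbon, that is, benzyl to 2-chlorobenzyl. Among the measured compounds shown here, with only two measured compounds, and those indistinguishable, there is no step of this kind to lean on. The expected step from compound 2 to compound 3 is a number 0.3 percentage points lower from compound 2 to compound 3 (within the scatter), none beyond the scatter. Compound 3 is therefore expected to give about 32%, within a range from 20% to 45%.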

Compound 3, a percentage reported as inhibition, in the whole organism at one dose (the size of the read-out at that dose, not a potency): 17.4%
For compound 3 the middle estimate is 14.6 percentage points above the measured one; measured number outside the range, below it.
By their numbers in this assay, from the lowest: compound 3; then compounds 1 and 2 (each within the scatter of the next).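

Among the compounds shown here, the first comparisons of a single change show that this position on the benzyl group matters: in this assay chloro in place of hydrogen gives a number 14.9 percentage points lower from compound 2 to compound 3 (beyond the scatter) with the 4-nitrophenyl group held fixed. The chlorine does not produce this alone, since with the 2-chlorobenzyl group held fixed, 4-nitrophenyl in place of 3,4-dimethoxyphenyl gives a number 12.9 percentage points lower from compound 1 to compound 3 (beyond the scatter) and so, among these three compounds, the low reading appears only where the chlorine and the 4-nitrophenyl group occur together. One chlorine atom is therefore enough to move this reading beyond the usual scatter, although a percentage at one dose gives the size of an effect and not a potency.

On these data alone, whether chloro in place of hydrogen would also lower the reading in a compound carrying the 3,4-dimethoxyphenyl group stays open, as does the outcome with a fluoro or methyl group in place of the chlorine. The reason for the drop also stays open, as nothing available on these compounds speaks to it.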